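Bromo in Place of Methyl on the Aryl Ring

The source may hold more compounds than are shown below. What is called first, only, known or untested is meant among the compounds shown, and "the series" means these compounds.

Of the compounds shown here, two have been measured in a functional assay on the whole organism for inhibition, with Rattus norvegicus as the target, read by paw edema, with a stated time of 1 h, at a dose of 50 mg/kg; on this read-out lower numbers stand for less inhibition and higher numbers for more inhibition at the one dose given (going by the name of the read-out). Compound 1 `CC(=O)c1c(NNc2ccc(Cl)cc2)cc(C)oc1=O` gives 54.4% there, and compound 2 `Cc1ccc(-n2nc3cc(C)oc(=O)c3c2C)cc1` gives 63.3%. Compound 2 holds the higher of the two numbers, yet its gap to compound 1 lies within the scatter, so the two numbers are to be taken as level. Compound 3 `Cc1cc2nn(-c3ccc(Br)cc3)c(C)c2c(=O)o1` differs from compound 2 in one place: bromo in place of methyl on an aromatic carbon. For the measured compounds named here, no measured pair shows such an exchange. For compound 3 the expected step in this assay is a number 3.3 percentage points lower from compound 2 to compound 3 (within the scatter), nothing beyond the scatter in either direction. Compound 3 is therefore estimated at 60%, with a range from 42% to 76%.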

Compound 3, a percentage reported as inhibition, in the whole organism at one dose (the size of the read-out at that dose, not a potency): 59.5%
The estimate for compound 3 lay 0.5 percentage points above the measured number, within the range that was stated.
By their numbers in this assay, from the lowest: compounds 1, 3 and 2 (each within the scatter of the next).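

For the compounds shown here, at the aromatic carbon para to a large group, the exchange of methyl for bromo gives a number 3.8 percentage points lower from compound 2 to compound 3 (within the scatter) in this assay and so leaves the read-out level, the first single exchange at this position that can be read. Bromo and methyl at this carbon cannot be told apart on this read-out at the one dose given. No measurement at hand speaks to the reason for this result. Going by these compounds, whether an amine, a carboxylic acid or a longer chain at this carbon would move the number beyond the scatter stays open. So does whether the same exchange would read alike elsewhere on the aromatic ring.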